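Trifluoromethyl in Place of Chloro on Compound 1

A few compounds are considered here, and "the series" means these few. Any claim that something is new, unique, unknown or untested is made for them only; others in the source may bear on it.

Measured compounds:
compound 1 `CC(C)(C)Cc1csc(N)c1C(=O)c1cccc(Cl)c1` — 8%
compound 2 `CC(C)(C)Cc1csc(N)c1C(=O)c1ccc(Cl)c(Cl)c1` — 10%

In an assay on CHO cells for displacement of a labelled ligand from adenosine receptor A3 (Homo sapiens), read by scintillation counting, tested at 10 uM (on this read-out lower numbers stand for less inhibition and higher numbers for more inhibition at the one concentration tested (going by the name of the read-out)), compound 1 gives 8%, which is where it stands on the two numbers available: at the bottom of the pair, with compound 2 within the scatter of it. In this assay compound 2 gives 10%. For the measured compounds named here, the only measured step, a number 2 percentage points higher from compound 1 to compound 2 (within the scatter), adds a chloro on an aromatic carbon and stays within the scatter, so it says little about what a different group at the existing chloro position might do.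

Compound 3 `CC(C)(C)Cc1csc(N)c1C(=O)c1cccc(C(F)(F)F)c1` differs from compound 1 by trifluoromethyl in place of chloro on an aromatic carbon. Going by the values given here, no measured step exchanges one group for another on the same aromatic carbon, so the expectation rests on how flat the known numbers are. Among the compounds with values here, both measured compounds sit low in this assay, and the one step between them stays within the scatter. The step of a number 1 percentage points higher from compound 1 to compound 3 (within the scatter) is therefore expected to be none beyond the scatter. For compound 3 the estimate in this assay is 9%, with a range from 0% to 24%.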

Compound 3, a percentage reported as inhibition, at one concentration (the size of the read-out at that concentration, not a potency): 1%
Beside the measured number, compound 3's estimate is 8 percentage points above it, within the range that was stated.
By their numbers in this assay, from the lowest: compounds 3, 1 and 2 (each within the scatter of the next).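

In this assay, the exchange of chloro for trifluoromethyl on an aromatic carbon of a six-membered aromatic ring of carbon only, meta to a large group, gives a number 7 percentage points lower from compound 1 to compound 3 (within the scatter). For the compounds shown here, this is the first measured exchange of one group for another at this position, as the earlier step only added a chloro, and replacing a group of 1 heavy atom with one of 4 heavy atoms leaves the result within the scatter. No measurement shown here offers an explanation for this result.

From the compounds shown here alone, whether an amine, a carboxylic acid or a longer chain on this same aromatic carbon would take the number beyond the scatter of compound 1 remains open. Going by these compounds, it also remains open whether a change elsewhere on the shared core would move the number in this assay beyond that scatter.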